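Swapping a halogen for a hydroxy group in a seizure model

A few compounds are considered here, and "the series" means these few. Any claim that something is new, unique, unknown or untested is made for them only; others in the source may bear on it.

Measured so far:
Compound 1, `SC1=NC(n2nc(-c3ccccc3)nc2-c2ccccc2)=CC(c2ccc(Cl)cc2)N1`: 30 mg/kg
Compound 2, `SC1=NC(n2nc(-c3ccccc3)nc2-c2ccccc2)=CC(c2ccccc2Cl)N1`: 30 mg/kg
Compound 3, `SC1=NC(n2nc(-c3ccccc3)nc2-c2ccccc2)=CC(c2ccc(Br)cc2)N1`: 100 mg/kg

All three compounds were tested in a functional assay on the whole organism with Mus musculus as the target, in the maximal electroshock model, with a stated time of 0.5 h; on this read-out lower numbers stand for an effect already at smaller amounts and higher numbers for an effect only at larger amounts of compound. Compound 3 gives the highest number of the three in this assay, standing a 3.3-fold higher number from compound 1 to compound 3 (0.52 log units; beyond the scatter) and a 3.3-fold higher number from compound 2 to compound 3 (0.52 log units; beyond the scatter); the two chlorophenyl compounds themselves show no change at the digits printed from compound 1 to compound 2 (within the scatter).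

The step to the untested compound 4, `Oc1ccc(C2C=C(n3nc(-c4ccccc4)nc3-c3ccccc3)N=C(S)N2)cc1`, is hydroxy in place of bromo on an aromatic carbon. For the measured compounds named here, none of the measured steps involves a hydroxy group; the only change on an aromatic carbon seen so far is the chloro-to-bromo step, which was modest. The data therefore give no firm direction for this step, only a sign that a single change at this position can move the number by a modest amount. Compound 4 is expected to fall around the middle of the range seen so far, with a 2.0-fold lower number from compound 3 to compound 4 (0.30 log units; within the scatter) as the estimated step. For compound 4 the estimate in this assay is 50 mg/kg, expected between 15 mg/kg and 150 mg/kg.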

Compound 4, minimum effective dose: 30 mg/kg
Compound 4: the middle estimate sits 1.7-fold (0.22 log units) above what was measured, within the range that was stated.
By their numbers in this assay, from the lowest: compounds 1, 2 and 4 (each within the scatter of the next); then compound 3.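

In this assay, a group quite unlike a halogen is tolerated at this position on an aromatic carbon, para to a large group: hydroxy, which brings a hydrogen-bond donor and acceptor that bromo lacks, gives a lower number than bromo (a 3.3-fold lower number from compound 3 to compound 4 (0.52 log units; beyond the scatter)). It also lands level with both chlorophenyl compounds (no change at the digits printed from compound 1 to compound 4 (within the scatter); no change at the digits printed from compound 2 to compound 4 (within the scatter)), so among these four compounds a halogen is not required for this level of effect, and compound 3 alone stands apart. No supporting measurement is available to explain why bromo differs from chloro and hydroxy here.

As far as these compounds go, what a methoxy group or an amine would give at this position stays open. So does the number for a plain phenyl ring with no group there at all.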